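Swapping the Outer Aryl Group on a Shared Core

The source may hold more compounds than are shown below. What is called first, only, known or untested is meant among the compounds shown, and "the series" means these compounds.

Of the compounds shown here, three built on one core have been measured in an assay on isolated protein for agonist activity at Bile acid receptor (Homo sapiens), read by AlphaScreen, with a stated time of 30 min; on this read-out lower numbers stand for an effect already at smaller amounts and higher numbers for an effect only at larger amounts of compound. Compound 1 `Cc1ccccc1-n1nc(C)c2c1NC(=O)[C@H](C)S[C@@H]2c1ccc(-c2ccoc2)cc1` gives 3500 nM, compound 2 `Cc1ccc(-n2nc(C)c3c2NC(=O)[C@H](C)S[C@@H]3c2ccc(Oc3ccccc3)cc2)cc1` gives 3400 nM, and compound 3 `CCOc1cccc(-c2ccc([C@H]3S[C@@H](C)C(=O)Nc4c3c(C)nn4-c3ccccc3C)cc2)c1` gives 3500 nM. Compound 3 thus sits level with compound 1, and its gap to compound 2 is within the scatter, so the three numbers are indistinguishable. Compound 4 `Cc1ccccc1-n1nc(C)c2c1NC(=O)[C@H](C)S[C@@H]2c1ccc(Oc2ccccc2)cc1` differs from compound 3 by phenoxy in place of 3-ethoxyphenyl on an aromatic carbon. Going by the values given here, the one comparable step, no change at the digits printed from compound 1 to compound 3 (within the scatter), showed that exchanging the outer aryl group left the number unchanged, and compound 2, which carries the same phenoxy group, gave a value within scatter of compound 3. Compound 4 is therefore expected to show a 1.0-fold lower number from compound 3 to compound 4 (0.01 log units; within the scatter). The estimated value for compound 4 is 3400 nM, in the range 1700 nM to 7000 nM.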

Compound 4, half-maximal effective concentration: 1300 nM
Beside the measured number, compound 4's estimate is 2.6-fold (0.42 log units) above it, outside the stated range (below it).
By their numbers in this assay, from the lowest: compound 4; then compounds 2, 1 and 3 (each within the scatter of the next).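

Phenoxy at this position, para to a large group, brings a change that the swap from furan-3-yl to 3-ethoxyphenyl did not: in this assay there is a step down against both other outer groups (a 2.7-fold lower number from compound 3 to compound 4 (0.43 log units; beyond the scatter); a 2.7-fold lower number from compound 1 to compound 4 (0.43 log units; beyond the scatter)). The group on the ring nitrogen also counts, with 2-methylphenyl in place of 4-methylphenyl giving a similar step (a 2.6-fold lower number from compound 2 to compound 4 (0.42 log units; beyond the scatter)). Among these four compounds, only phenoxy paired with 2-methylphenyl gives the lower number.

No available data explain this pairing. As far as these compounds go, whether an amine or a carboxylic acid on the outer phenyl ring would keep the lower number stays open.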